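Aryl ester variation on a shared core

The source may report more compounds than this note shows. Statements on the series, on what has been measured and on what is new or still open speak of the compounds shown alone.

Compound 1 `C=C1C(=O)O[C@@H]2CC(C)=C([C@@H](C)CCCOC(C)=O)[C@@H](OC(=O)COc3cccc(C(C)=O)c3)[C@H]12` gives 38600 nM
Compound 2 `C=C1C(=O)O[C@@H]2CC(C)=C([C@@H](C)CCCOC(C)=O)[C@@H](OC(=O)COc3ccc([N+](=O)[O-])cc3[N+](=O)[O-])[C@H]12` gives > 100000 nM
Compound 3 `C=C1C(=O)O[C@@H]2CC(C)=C([C@@H](C)CCCOC(C)=O)[C@@H](OC(=O)COc3ccc4c(CC)noc4c3)[C@H]12` gives 21700 nM

In a functional assay on HeLa cells (Homo sapiens) for cytotoxicity, read by sulforhodamine B assay, with a stated time of 72 h (on this read-out higher numbers stand for weaker inhibition and lower numbers for stronger inhibition), compound 1 holds the higher of the two numbers, and its nearest neighbour, compound 3, sits within the scatter. For compound 2 the value is a limit of this assay, not a number (the limit of > 100000 nM in this assay, at which 1 of the 3 values shown sits). Compound 4 `C=C1C(=O)O[C@@H]2CC(C)=C([C@@H](C)CCCOC(C)=O)[C@@H](OC(=O)c3ccccc3F)[C@H]12` carries a (2-fluorophenyl in place of (3-acetylphenoxy)methyl on a carbonyl carbon). The measured steps only swap the aryl ring on the oxygen of that side chain: an at least 2.5-fold higher number from compound 1 to compound 2 (0.41 log units; beyond the scatter), and a 1.8-fold lower number from compound 1 to compound 3 (0.25 log units; within the scatter). Neither removes the oxygen and methylene that the change to compound 4 removes, so they bear on it only loosely. The step is expected to be a 1.0-fold higher number from compound 1 to compound 4 (0.02 log units; within the scatter), none beyond the scatter. Compound 4 is estimated at 40000 nM, ranging from 15000 nM to 100000 nM.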

Compound 4, half-maximal inhibitory concentration: 17000 nM
Compound 4: the middle estimate sits 2.4-fold (0.37 log units) above what was measured; measured number inside the range.
By their numbers in this assay, from the lowest: compounds 4, 3 and 1 (each within the scatter of the next, the first and the last beyond it). At a limit, above all of these: compound 2.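

In this assay, 2-fluorophenyl in place of (3-acetylphenoxy)methyl on a carbonyl carbon gives a 2.3-fold lower number from compound 1 to compound 4 (0.36 log units; beyond the scatter). Unlike the earlier swaps of the aryl ring, this change removes the oxygen and methylene of the side chain, and the number does not rise but falls modestly, so that link is not needed for the activity seen here. Nothing measured here accounts for the step. As far as these compounds go, whether the fall follows the shorter group or the fluorine stays open, as does how an amine or a carboxylic acid in place of the fluorine would read.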